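Working notes: the step from compound 3 to compound 4

The compounds below may be only part of what the source reports. "The series", "measured", "known", "first", "only" and "open" are said of these compounds alone.

- compound 1 `NC(=O)c1ccc2[nH]c(-c3ccc(OCC4CCNCC4)cc3)nc2c1`: > 400000 nM (a limit of the assay)
- compound 2 `NC(=O)c1ccc2[nH]c(-c3ccc(OCCC4CCN(Cc5ccccc5)CC4)cc3)nc2c1`: 5000 nM
- compound 3 `CC(=O)N1CCC(COc2ccc(-c3nc4cc(C(N)=O)ccc4[nH]3)cc2)CC1`: "not determined" (no result reported)

All three entries come from a physicochemical assay for solubility, with a stated time of 3 days, at pH 7; a lower number here means a less soluble compound, a higher number a more soluble compound. Compound 3 has no number to stand on, as its result reads "not determined" (no result reported). Compound 1 sits at the limit of > 400000 nM in this assay, at which 1 of the 3 values shown sits, which is a limit and not a number. Going by the values given here, compound 2, at 5000 nM, gives the only measured number.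

The next structure is compound 4 `CC(=O)N1CCC(CCOc2ccc(-c3nc4cc(C(N)=O)ccc4[nH]3)cc2)CC1`. The change is (1-acetylpiperidin-4-yl)methyl in place of 1-acetylpiperidin-4-yl on a saturated chain carbon bound to an oxygen on an aromatic ring, with (1-acetylpiperidin-4-yl)methyl in place of 1-acetylpiperidin-4-yl on a saturated chain carbon bound to an oxygen on an aromatic ring.

Among the compounds with values here, no step between measured compounds bears on this change, so the expectation is loose. A small downward step in this assay is expected on going to compound 4, not far beyond the scatter, though without a number for compound 3 it could not be read directly. The low side of the expectation is anchored by compound 2 at 5000 nM. The high side is left open by the limit of compound 1.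

For compound 4 the solubility is estimated at 60000 nM, with an expected range of 10000 nM to 300000 nM.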

Compound 4, solubility: 2000 nM
Compound 4: middle estimate off by 30-fold (1.48 log units), on the high side; the measured number lies below the stated range.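

In this assay, going by these compounds alone, acetyl in place of benzyl on an amine nitrogen in a ring gives a 2.5-fold lower number from compound 2 to compound 4 (0.40 log units; beyond the scatter), the first readable step, and it runs downward: with the chain the same in both compounds, the acetyl compound does not read higher than the benzyl compound. (1-Acetylpiperidin-4-yl)methyl in place of piperidin-4-yl on a saturated chain carbon bound to an oxygen on an aromatic ring gives an at least 200-fold lower number from compound 1 to compound 4 (2.30 log units; beyond the scatter), the larger of the two new steps, and it places the free piperidine compound well apart from the acetyl compound on this read-out. The value of compound 1 is a limit of the assay and not a number: the limit of > 400000 nM in this assay, at which 1 of the 4 values shown sits.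

The step from compound 3 to compound 4 cannot be read, as compound 3 carries no result, and the change from 1-acetylpiperidin-4-yl to (1-acetylpiperidin-4-yl)methyl on its own remains without a number. Also open, on these data alone, is how a longer chain, or a methyl or a methanesulfonyl group on the amine nitrogen in a ring, would read in this assay.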